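The source may hold more compounds than are shown below. What is called first, only, known or untested is meant among the compounds shown, and "the series" means these compounds.

Measured compounds:

compound 1, `COc1ccc(-c2cc3cc(-c4ccc(F)cc4)cc(C(C)=O)c3[nH]2)cc1`, in a functional assay on HeLa cells (Homo sapiens) for cytotoxicity, read by MTT assay, with a stated time of 2 days, tested at 10 uM (a higher number here means a weaker effect of the compound at the concentration tested, a lower number a stronger effect), compound 1 gives 52%
compound 2, `COc1ccc(-c2cc(C(C)=O)c3[nH]c(-c4ccc(OC)cc4)cc3c2)cc1`, in this assay compound 2 gives 37.1%
compound 3, `CC(=O)c1cc(/C=C/c2ccc(F)cc2)cc2cc(-c3ccc(F)cc3)[nH]c12`, in this assay compound 3 gives 41.9%

Compound 1 and compound 2 share a core and differ in one place: methoxy in place of fluoro on an aromatic carbon. This change is tied to a step of a number 14.9 percentage points lower from compound 1 to compound 2 (beyond the scatter), a modest move toward a stronger effect at the concentration tested.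

Compound 3 carries the same kind of acetyl-bearing core as compound 1, but how the two cores differ is not broken down here. In this assay the number for compound 3 lies between those of compound 1 and compound 2; against compound 2 the gap is within the scatter, against compound 1 it is beyond it.

Compound 4, `COc1ccc(-c2cc3cc(/C=C/c4ccc(F)cc4)cc(C(C)=O)c3[nH]2)cc1`, is not yet measured. It stands to compound 3 as compound 2 stands to compound 1: methoxy in place of fluoro on an aromatic carbon. The place of the change reads the same in both pairs, so it is the same change made on a second core.

For the measured compounds named here, with only one earlier instance of this change, the expectation for compound 4 rests on the step of a number 14.9 percentage points lower from compound 1 to compound 2 (beyond the scatter) seen from compound 1 to compound 2 in this assay. On that basis a step of about a number 14.9 percentage points lower from compound 3 to compound 4 (beyond the scatter) is expected from compound 3 to compound 4 in this assay. For compound 4 in this assay a value near 27% is estimated, most likely between 15% and 40%.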

Compound 4, a percentage reported as activity, at one concentration (the size of the read-out at that concentration, not a potency): 25.8%
Estimate against measurement, compound 4: 1.2 percentage points above; measured number inside the range.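

In this assay the change from 4-fluorophenyl to 4-methoxyphenyl goes with a number 16.1 percentage points lower from compound 3 to compound 4 (beyond the scatter), so the step seen on the core of compound 1 carries over to the core of compound 3 at about the same size: the same change on two cores in this assay, a number 14.9 percentage points lower (beyond the scatter) from compound 1 to compound 2 and a number 16.1 percentage points lower (beyond the scatter) from compound 3 to compound 4, 1.2 percentage points apart, within the scatter of two such steps. Compound 4 also differs in one place from two other compounds, with a number 11.3 percentage points lower from compound 2 to compound 4 (beyond the scatter) where 2-(4-fluorophenyl)ethenyl replaces 4-methoxyphenyl, and a number 26.2 percentage points lower from compound 1 to compound 4 (beyond the scatter) where it replaces 4-fluorophenyl. These two matched pairs show that the change behaves alike on these two closely related cores at the single concentration tested, but they give no potency, do not explain the step, and do not show that it would hold on any other core.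

On these data alone, all four compounds keep the acetyl group and carry only fluoro or methoxy on the aromatic rings, so it remains open how the numbers would move with a hydroxyl group, an amine or a carboxylic acid at the carbon where methoxy now sits. As far as these compounds go, the part played by the acetyl group itself also remains open, for instance against a simple hydrogen or a longer acyl chain at that place.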